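This account rests on a few compounds, and the source may have more. Where it says the series, first, only, none or still open, it means among the compounds named here.

Measured so far in a functional assay on OVCAR-5 cells (Homo sapiens) for antiproliferative activity; on this read-out higher numbers stand for weaker inhibition of growth and lower numbers for stronger inhibition of growth:
Compound 1 `CCOC(=O)C[C@H]1[C@@H](O[Si](C)(C)C(C)(C)C)[C@H](n2cnc3c(NC(=O)Nc4ccccc4)ncnc32)O[C@@H]1COC(=O)NC` gives 12.8 nM.
Compound 2 `CNC(=O)NC[C@H]1O[C@@H](n2cnc3c(NC(=O)Nc4ccccc4)ncnc32)[C@H](O[Si](C)(C)C(C)(C)C)[C@@H]1CC(=O)N(C)OC` gives 38.2 nM.

Among these two numbers compound 2 stands highest, that is, it is the weaker of the pair in this assay; the nearest number, that of compound 1, is lower by a gap beyond the usual scatter. Compound 3 `CCOC(=O)C[C@H]1[C@@H](O[Si](C)(C)C(C)(C)C)[C@H](n2cnc3c(NC(=O)Nc4ccccc4)ncnc32)O[C@@H]1CNC(=O)NC` has not yet been measured. It differs from compound 2 in one place: ethoxy in place of methoxy(methyl)amino on a carbonyl carbon. Among the measured compounds shown here, no directly comparable pair of measured compounds shows what this exchange alone does, but compound 1, which also carries the ethoxycarbonyl group, gives 12.8 nM in this assay, a lower number than compound 2. On that basis the expected step is a 1.7-fold lower number from compound 2 to compound 3 (0.24 log units; within the scatter), a modest move toward stronger inhibition that may not clearly exceed the scatter. Compound 3 is therefore estimated to give about 22 nM, within a range from 8 nM to 55 nM.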

Compound 3, concentration for 50% growth inhibition: 31.1 nM
Estimate against measurement, compound 3: 1.4-fold (0.15 log units) below; low and high end bracket the measured number.
By their numbers in this assay, from the lowest: compound 1; then compounds 3 and 2 (each within the scatter of the next).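

In this assay, the exchange of methoxy(methyl)amino for ethoxy on a carbonyl carbon gives a 1.2-fold lower number from compound 2 to compound 3 (0.09 log units; within the scatter), so the two groups cannot be told apart at this position. The second comparison, (methylcarbamoyl)amino in place of (methylcarbamoyl)oxy on a saturated chain carbon bound to a saturated ring carbon, gives a 2.4-fold higher number from compound 1 to compound 3 (0.39 log units; beyond the scatter), which shows that the ethoxycarbonyl group alone does not bring the lower number of compound 1 and that this other position also matters. Nothing shown here explains either result.

From the compounds shown here alone, it remains open how a carboxylic acid or a primary amide would read on that carbonyl carbon. Going by these compounds, it is also open whether the (methylcarbamoyl)oxy group would give the same step when paired with methoxy(methyl)amino instead of ethoxy.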